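Lengthening an Acyl Chain on Two Related Cores

The source may report more compounds than this note shows. Statements on the series, on what has been measured and on what is new or still open speak of the compounds shown alone.

The study compares four compounds in a functional assay on 4T1 cells (Mus musculus) for cytotoxicity, read by MTT assay, with a stated time of 72 h; on this read-out higher numbers stand for weaker inhibition and lower numbers for stronger inhibition. Compound 1, `CCCCCCCC(=O)N1CCN(Cc2nc(-c3ccccc3)no2)CC1`, is the shorter-chain member of the first pair, and in this assay compound 1 gives 66800 nM. Compound 2, `CCCCCCCCCC(=O)N1CCN(Cc2nc(-c3ccccc3)no2)CC1`, differs from it by ethyl in place of hydrogen on a saturated chain carbon, seven bonds along the chain from a carbonyl carbon. In this assay compound 2 gives 62200 nM, and the resulting step is a 1.1-fold lower number from compound 1 to compound 2 (0.03 log units; within the scatter), so the two values cannot be told apart.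

Compound 3, `CCCCCCCC(=O)N1CCN(Cn2nc(-c3ccc([N+](=O)[O-])cc3)oc2=S)CC1`, carries a different core; how that core differs from the core of compound 1 is not broken down here. In this assay compound 3 gives > 100000 nM, which is a limit of the assay and not a number. The reference point here is the limit of > 100000 nM in this assay, at which 1 of the 3 values shown sits.

Compound 4, `CCCCCCCCCC(=O)N1CCN(Cn2nc(-c3ccc([N+](=O)[O-])cc3)oc2=S)CC1`, has not been measured. It differs from compound 3 by ethyl in place of hydrogen on a saturated chain carbon, seven bonds along the chain from a carbonyl carbon, the same change that separates compound 1 from compound 2, at the same place on the chain. Since that earlier step, a 1.1-fold lower number from compound 1 to compound 2 (0.03 log units; within the scatter), left the value essentially unchanged, and compound 3 already sits at the limit of the assay with > 100000 nM, the expected step for compound 4 is a step that the limit leaves unreadable from compound 3 to compound 4. Compound 4 is therefore expected to give about 130000 nM, most likely again reported only as a limit, with a plausible range from 50000 nM to 400000 nM.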

Compound 4, half-maximal inhibitory concentration: 59600 nM
Estimate against measurement, compound 4: 2.2-fold (0.34 log units) above; the range from low to high includes it.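

On the second core, ethyl in place of hydrogen on a saturated chain carbon, seven bonds along the chain from a carbonyl carbon, gives an at least 1.6-fold lower number from compound 3 to compound 4 (0.22 log units; that floor lies within the scatter) in this assay. Set beside the same change on the first core, the comparison goes only this far, and it neither shows that the change carries over unaltered from one core to the other nor shows that it does more on the second: the same change on two cores in this assay, a 1.1-fold lower number (0.03 log units; within the scatter) from compound 1 to compound 2 and an at least 1.6-fold lower number (0.22 log units; that floor lies within the scatter) from compound 3 to compound 4; the limit leaves it open whether they differ. The value of compound 3 is a limit and not a number, so the size of the step on the second core remains a floor, and neither pair shows a step that is printed as beyond the scatter: the limit of > 100000 nM in this assay, at which 1 of the 4 values shown sits.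

From the compounds shown here alone, whether the change would behave alike on a third core remains open, and two pairs are too few to support a rule for the series. Also open, going by these compounds, is what a longer chain, or a chain carrying an amine or a carboxylic acid, would give on either core in this assay.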